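Aryl amide swap on the shared core, cytotoxicity check

The compounds below may be only part of what the source reports. "The series", "measured", "known", "first", "only" and "open" are said of these compounds alone.

Compound 1 `Cc1ccc(S(=O)(=O)N[C@@H](CC(=O)NC(C)(C)C)C(=O)NCCNC(=O)c2cc(Cl)ccn2)cc1` carries a 4-chloropyridin-2-yl group on a carbonyl carbon. In an ADME assay on Karpas-1106P cells (Homo sapiens) for cytotoxicity (on this read-out lower numbers stand for an effect already at smaller amounts and higher numbers for an effect only at larger amounts of compound), compound 1 gives only a limit, > 11100 nM. Compound 2 `Cc1ccc(S(=O)(=O)N[C@@H](CC(=O)NC(C)(C)C)C(=O)NCCNC(=O)c2cccc(F)c2)cc1` likewise gives a limit in this assay, > 11100 nM. Compound 3 `Cc1ccc(S(=O)(=O)N[C@@H](CC(=O)NC(C)(C)C)C(=O)NCCNC(=O)c2cccc(C#N)c2)cc1` also gives a limit in this assay, > 11100 nM. All three values sit at the limit of > 11100 nM in this assay, at which 3 of the 3 values shown sit, so a step that the two limits leave unreadable from compound 1 to compound 2, a step that the two limits leave unreadable from compound 1 to compound 3 and a step that the two limits leave unreadable from compound 2 to compound 3 stay unreadable. Compound 4 `Cc1ccc(S(=O)(=O)N[C@@H](CC(=O)NC(C)(C)C)C(=O)NCCNC(=O)c2cc(C)ccc2F)cc1` is not yet measured; its change from compound 1 is 2-fluoro-5-methylphenyl in place of 4-chloropyridin-2-yl on a carbonyl carbon. The related aryl swaps from compound 1 gave no readable size, so no step beyond the scatter is expected from compound 1 to compound 4 in this assay. Compound 4 is expected to give 15000 nM, within 8000 nM to 40000 nM, most probably again as a limit. This implies an expected step that the limit leaves unreadable from compound 1 to compound 4.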

Compound 4, half-maximal effective concentration: > 11100 nM
Compound 4 was reported as a limit; the forecaster's own chance of this, stated with the estimate: 85%; the middle value does not contradict the limit.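

The steps from compound 1, compound 2 and compound 3 to compound 4 cannot be read, and all four compounds share one result: the limit of > 11100 nM in this assay, at which 4 of the 4 values shown sit.

Which change to the shared core, if any, would give a value rather than a limit in this assay stays open.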